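This account rests on a few compounds, and the source may have more. Where it says the series, first, only, none or still open, it means among the compounds named here.

Of the compounds shown here, three sharing one urea core have been measured in an assay on HEK293 cells for activation of Kir3.1/Kir3.2 (Homo sapiens), read by fluorescence and thallium flux, with a stated time of 4 min; on this read-out lower numbers stand for an effect already at smaller amounts and higher numbers for an effect only at larger amounts of compound. Compound 1 `Cc1ccc(NC(=O)Nc2ccccc2)cc1S(=O)(=O)N(C)C` gives 1400 nM, compound 2 `Cc1ccc(NC(=O)Nc2ccc(Cl)cc2)cc1S(=O)(=O)N(C)C` gives 3300 nM, and compound 3 `COc1ccc(NC(=O)Nc2ccc(C)c(S(=O)(=O)N(C)C)c2)cc1` gives 1700 nM. Compound 3 stands second highest of the three numbers, with compound 1 and compound 2 both within the scatter of it. Compound 4 `Cc1ccc(NC(=O)Nc2ccccc2F)cc1S(=O)(=O)N(C)C` differs from compound 3 by 2-fluorophenyl in place of 4-methoxyphenyl on an amide-type nitrogen. Among the compounds with values here, no measured step introduces fluorine on that phenyl group; the nearest guides are a 2.4-fold higher number from compound 1 to compound 2 (0.37 log units; beyond the scatter), a 1.2-fold higher number from compound 1 to compound 3 (0.08 log units; within the scatter) and a 1.9-fold lower number from compound 2 to compound 3 (0.29 log units; within the scatter), all modest or within the scatter. A step of similar small size is therefore expected in this assay, a 1.1-fold higher number from compound 3 to compound 4 (0.02 log units; within the scatter), with its direction uncertain. Compound 4 is estimated at 1800 nM, within a range of 800 nM to 4000 nM.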

Compound 4, half-maximal effective concentration: 3900 nM
Beside the measured number, compound 4's estimate is 2.2-fold (0.34 log units) below it; measured number inside the range.
By their numbers in this assay, from the lowest: compounds 1, 3, 2 and 4 (each within the scatter of the next, the first and the last beyond it).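

Fluoro in place of hydrogen gives a 2.8-fold higher number from compound 1 to compound 4 (0.44 log units; beyond the scatter), the largest step so far in this assay, and 2-fluorophenyl in place of 4-methoxyphenyl gives a 2.3-fold higher number from compound 3 to compound 4 (0.36 log units; beyond the scatter). 2-fluorophenyl in place of 4-chlorophenyl gives a 1.2-fold higher number from compound 2 to compound 4 (0.07 log units; within the scatter), so among these compounds both halogen-bearing phenyl groups, in compound 2 and compound 4, lie beyond the scatter of compound 1, whereas the methoxy group of compound 3 does not. No available evidence explains these steps. Still open, as far as these compounds go, is whether the halogen itself or its place on the phenyl group sets the step, and how an amine or a carboxylic acid there would read.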